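Benzyl thioether cut down to carboxymethyl

The source may report more compounds than this note shows. Statements on the series, on what has been measured and on what is new or still open speak of the compounds shown alone.

Compound 2 `N#Cc1c(C2CCCCC2)nc(SCc2ccccc2)[nH]c1=O` holds the highest number of the two measured compounds: in an assay on isolated protein for inhibition of Rap guanine nucleotide exchange factor 4 (Homo sapiens), read by fluorescence and cAMP accumulation (on this read-out higher numbers stand for weaker inhibition and lower numbers for stronger inhibition), compound 2 gives 30500 nM, while compound 1 `Cc1cc(C)cc(CSc2nc(C3CCCCC3)c(C#N)c(=O)[nH]2)c1` gives 7000 nM. Within the data shown here, the only measured step, a 4.4-fold higher number from compound 1 to compound 2 (0.64 log units; beyond the scatter), already moved the number upward. Compound 3 `N#Cc1c(C2CCCCC2)nc(SCC(=O)O)[nH]c1=O` differs from compound 2 by carboxy in place of phenyl on a saturated chain carbon bound to a sulfur. Among the measured compounds shown here, no measured step covers this exchange; the step from compound 1 to compound 2 bears on it only as a sign that trimming the benzyl side raised the number. A further upward shift in this assay is therefore expected for compound 3, roughly a 2.0-fold higher number from compound 2 to compound 3 (0.29 log units; within the scatter). The estimate for compound 3 is 60000 nM, with a range from 15000 nM to 250000 nM.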

Compound 3, half-maximal inhibitory concentration: > 300000 nM
Compound 3: no number, only a limit; the forecaster's own chance of this, stated with the estimate: 35%; middle value at least 5.0-fold (0.69 log units) away from the limit.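

Earlier, only the two methyl groups on the aromatic ring had changed; here the ring itself leaves the saturated chain carbon bound to a sulfur. Carboxy in place of phenyl gives an at least 9.8-fold higher number from compound 2 to compound 3 (0.99 log units; beyond the scatter), and carboxy in place of 3,5-dimethylphenyl gives an at least 42-fold higher number from compound 1 to compound 3 (1.63 log units; beyond the scatter). For compound 3, this assay returns no number, only a limit: the limit of > 300000 nM in this assay, at which 1 of the 3 values shown sits.

Going by these compounds, the true size of both steps remains open, as does whether they follow from the loss of the ring or the entry of carboxy. A cyclohexyl group or a methyl ester in this place could separate the two.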